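The source may hold more compounds than are shown below. What is called first, only, known or untested is meant among the compounds shown, and "the series" means these compounds.

Among the measured compounds shown here, in an ADME assay on the whole organism (muscle tissue) for activation, with Mus musculus as the target, in the rotarod test, with a stated time of 30 min (on this read-out lower numbers stand for an effect already at smaller amounts and higher numbers for an effect only at larger amounts of compound), compound 1 `O=C1CN(/N=C/c2ccc(-c3cccc(C(F)(F)F)c3)o2)C(=O)N1` gives 166 mg/kg as the only number so far. Compound 2 `Nc1ccc(-c2ccc(/C=N/N3C(=O)NC(=O)C3O)o2)cc1` reads > 1000 mg/kg and that is a limit of the assay, not a number. Compound 3 `O=C1NC(=O)N(/N=C/c2ccc(-c3cccc(C(F)(F)F)c3)o2)C1O` differs from compound 1 by hydroxy in place of hydrogen on a saturated ring carbon with hydroxy in place of hydrogen on a saturated ring carbon. For the measured compounds named here, with no measured step between compounds differing in one place, the size of the step in this assay is a judgement starting from compound 1 at 166 mg/kg alone: a moderate move towards larger doses is expected. The estimated move is a 2.1-fold higher number from compound 1 to compound 3 (0.32 log units; beyond the scatter) in size. Compound 3 is expected at 350 mg/kg with an estimated range from 120 mg/kg to 1000 mg/kg as the working figure.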

Compound 3, dose for half-maximal effect: 85 mg/kg
Beside the measured number, compound 3's estimate is 4.1-fold (0.61 log units) above it; measured number outside the range, below it.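

In this assay, hydroxy in place of hydrogen on a saturated ring carbon gives a 2.0-fold lower number from compound 1 to compound 3 (0.29 log units; within the scatter). This first one-place pair therefore shows that the position carries hydroxy with no step beyond the scatter, and compound 1 and compound 3 cannot be ordered. Nothing shown on these compounds accounts for the step.

From the compounds shown here alone, whether a methoxy group, an amine or a methyl group on the same ring carbon would read alike remains open. Compound 2 reads > 1000 mg/kg, which is a limit and not a number, so it leaves the hydroxy change on a different aryl group unresolved.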